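Chain Extension at the Amide Nitrogen of a Thiazolidinone Scaffold

The source may hold more compounds than are shown below. What is called first, only, known or untested is meant among the compounds shown, and "the series" means these compounds.

Measured compounds:
compound 1 `CCN(CC)CCCn1c(=O)c(=Cc2ccc(F)c(F)c2)s/c1=C1\C(=O)Nc2cc(F)ccc21`: 1120 nM
compound 2 `CN(C)CCn1c(=O)c(=Cc2ccc(F)cc2F)s/c1=C1\C(=O)Nc2cc(F)ccc21`: 3200 nM

In a functional assay on NCI-H460 cells (Homo sapiens) for inhibition, read by MTT assay, with a stated time of 72 h (on this read-out lower numbers stand for stronger inhibition and higher numbers for weaker inhibition), compound 2 gives the higher of the two numbers, and its gap to compound 1 lies beyond the usual scatter. Compound 3 `CCN(CC)CCCn1c(=O)c(=Cc2ccc(F)cc2F)s/c1=C1\C(=O)Nc2cc(F)ccc21` is not yet measured. It differs from compound 2 by (diethylamino)methyl in place of dimethylamino on a saturated chain carbon, two bonds along the chain from an aromatic nitrogen; the aryl group stays as in compound 2. Without a measured pair showing this chain change alone, only a modest shift is expected. The step from compound 2 to compound 3 is expected to be a 1.8-fold lower number from compound 2 to compound 3 (0.25 log units; within the scatter), toward a lower number. Compound 3 is therefore estimated at 1800 nM, within 700 nM to 4500 nM.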

Compound 3, half-maximal inhibitory concentration: 2330 nM
Compound 3: the middle estimate sits 1.3-fold (0.11 log units) below what was measured, and the stated range covers the measured number.
By their numbers in this assay, from the lowest: compound 1; then compounds 3 and 2 (each within the scatter of the next).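

Changing 2-(dimethylamino)ethyl to 3-(diethylamino)propyl gives a 1.4-fold lower number from compound 2 to compound 3 (0.14 log units; within the scatter) in this assay and so has no clear effect at this position. Among these compounds, with 3-(diethylamino)propyl held constant, placing 2,4-difluorophenyl in place of 3,4-difluorophenyl gives a 2.1-fold higher number from compound 1 to compound 3 (0.32 log units; beyond the scatter) and is the only one of these steps beyond the scatter. No measurement shown here explains either step.

The compounds shown leave open whether a morpholine on the chain or a longer chain would change the number, and whether the aryl step also holds with 2-(dimethylamino)ethyl.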